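A few compounds are considered here, and "the series" means these few. Any claim that something is new, unique, unknown or untested is made for them only; others in the source may bear on it.

Compound 1 `Cc1ccc(N2C(=O)C/C(=C\c3cccc(C(=O)Nc4cccc(F)c4)c3)C2=O)cc1` was examined in an ADME assay on NCM460 cells (Homo sapiens) for cytotoxicity, read by MTT assay, with a stated time of 72 h; on this read-out lower numbers stand for stronger inhibition and higher numbers for weaker inhibition. In this assay compound 1 gives only a limit, > 100000 nM, not a measured number. Compound 2 `CCc1cccc(NC(=O)c2cccc(/C=C3\CC(=O)N(Cc4ccccc4)C3=O)c2)c1` likewise gives only a limit in this assay, > 100000 nM. The two results thus share one boundary: the limit of > 100000 nM in this assay, at which 2 of the 2 values shown sit. Compound 3 `COc1ccc(NC(=O)c2cccc(/C=C3\CC(=O)N(c4ccc(C)cc4)C3=O)c2)cc1` has not yet been measured; it differs from compound 1 by 4-methoxyphenyl in place of 3-fluorophenyl on an amide-type nitrogen. Among the compounds with values here, no measured pair shows what such a change does here, so no movement beyond the usual scatter is expected. Compound 3 is therefore expected to give 150000 nM, within a range from 50000 nM to 500000 nM, most likely again as a limit. That amounts to an expected step that the limit leaves unreadable from compound 1 to compound 3.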

Compound 3, half-maximal inhibitory concentration: > 100000 nM
Compound 3 ended at the assay's limit; the forecaster's own chance of this, stated with the estimate: 85%; the middle value lies beyond the limit too.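

In this assay, within the data shown here, compound 1 and compound 3 both give only limits, not measured numbers, so no step between them can be read. The compounds shown leave open what 4-methoxyphenyl in place of 3-fluorophenyl actually changes.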